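Naphthalen-1-yl replaces 3,5-dimethoxyphenyl on the shared core

The source may hold more compounds than are shown below. What is called first, only, known or untested is meant among the compounds shown, and "the series" means these compounds.

Of the compounds shown here, two built on one core have been measured in an ADME assay on L6 cells (Rattus norvegicus) for cytotoxicity, read by resazurin assay; on this read-out higher numbers stand for weaker inhibition and lower numbers for stronger inhibition. Compound 1 `N=C(N)c1ccc2[nH]c(-c3ccc4nc(-c5ccc(F)cc5)[nH]c4c3)nc2c1` gives 2.48 ug/mL, while compound 2 `COc1cc(OC)cc(-c2nc3ccc(-c4nc5cc(C(=N)N)ccc5[nH]4)cc3[nH]2)c1` gives 25.5 ug/mL, the higher of the two numbers. Compound 3 `N=C(N)c1ccc2[nH]c(-c3ccc4nc(-c5cccc6ccccc56)[nH]c4c3)nc2c1` keeps the core of compound 2 and changes a single group, with naphthalen-1-yl in place of 3,5-dimethoxyphenyl on an aromatic carbon.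

For the measured compounds named here, only one measured step bears on this change, and it involves the same aromatic carbon: a 10-fold higher number from compound 1 to compound 2 (1.01 log units; beyond the scatter). That large step, where 3,5-dimethoxyphenyl replaced 4-fluorophenyl, shows that the number can move far when this group is exchanged. A single step cannot show which feature of the group matters. Compound 2 stands at the high end, and it alone carries oxygen in this group, so a move back towards compound 1 at 2.48 ug/mL seems likely, though not all the way. A smaller downward change is expected, with an estimated step of a 4.3-fold lower number from compound 2 to compound 3 (0.63 log units; beyond the scatter). For compound 3 the estimated value is 6 ug/mL, with an expected range of 1.5 ug/mL to 22 ug/mL.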

Compound 3, half-maximal inhibitory concentration: 8.72 ug/mL
Compound 3: middle estimate off by 1.5-fold (0.16 log units), on the low side; the range from low to high includes it.
By their numbers in this assay, from the lowest: compound 1; then compound 3; then compound 2.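

In this assay, the naphthalen-1-yl group keeps the 10 heavy atoms of 3,5-dimethoxyphenyl but contains carbon only and has no hydrogen-bond acceptors, and this exchange gives a 2.9-fold lower number from compound 2 to compound 3 (0.47 log units; beyond the scatter). Measured against the 4-fluorophenyl group, the same naphthalen-1-yl group gives a 3.5-fold higher number from compound 1 to compound 3 (0.55 log units; beyond the scatter), so a second oxygen-free group also sits lower than the dimethoxy compound, yet the two oxygen-free groups still differ from each other beyond the usual scatter. Among these three compounds, then, lacking oxygen in this group goes with a lower number but does not fix its size, and no independent measurement is available to explain the differences.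

The three groups differ in several features at once, so the roles of the methoxy oxygens, the fluorine and the second aromatic ring cannot be separated. Going by these compounds, an unsubstituted phenyl or a 3,5-dimethylphenyl group on the same aromatic carbon would be a closer comparison, and whether a single methoxy group behaves like the pair also remains open.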